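Swapping the aryl amine substituent in a cyanopyrimidine series

The source may report more compounds than this note shows. Statements on the series, on what has been measured and on what is new or still open speak of the compounds shown alone.

Of the compounds shown here, three sharing one core have been tested in a functional assay on MGC-803 cells (Homo sapiens) for inhibition, read by MTT assay, with a stated time of 72 h; on this read-out higher numbers stand for weaker inhibition and lower numbers for stronger inhibition. Compound 1 `COc1ccc(Nc2nc(SCc3cn(Cc4ccccc4Cl)nn3)nc(-c3ccccc3)c2C#N)cc1` gives 7560 nM. Compound 2 `N#Cc1c(Nc2cccc(Cl)c2)nc(SCc2cn(Cc3ccccc3Cl)nn2)nc1-c1ccccc1` gives 15800 nM. Compound 3 `COc1ccccc1Nc1nc(SCc2cn(Cc3ccccc3Cl)nn2)nc(-c2ccccc2)c1C#N` gives 5800 nM, the lowest number of the three, although its gap to compound 1 is within the scatter; the step of a 1.3-fold lower number from compound 1 to compound 3 (0.12 log units; within the scatter) shows this. The step of a 2.1-fold higher number from compound 1 to compound 2 (0.32 log units; beyond the scatter) and the step of a 2.7-fold lower number from compound 2 to compound 3 (0.44 log units; beyond the scatter) both point the same way: the compound carrying a 3-chlorophenyl gives the weakest inhibition.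

Compound 4 `Cc1cccc(Nc2nc(SCc3cn(Cc4ccccc4Cl)nn3)nc(-c3ccccc3)c2C#N)c1` has not yet been measured. It differs from compound 3 in one place: 3-methylphenyl in place of 2-methoxyphenyl on a nitrogen on an aromatic ring. Among the compounds with values here, no measured step changes exactly this pair of groups, but the two steps involving compound 2 bear on it, since a 3-substituted phenyl again replaces a methoxyphenyl. A modest rise in the number is therefore expected, comparable to those steps. Compound 4 is estimated at 10000 nM, ranging from 4500 nM to 25000 nM, which is expected to mean a step of a 1.7-fold higher number from compound 3 to compound 4 (0.24 log units; within the scatter).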

Compound 4, half-maximal inhibitory concentration: 16200 nM
Estimate against measurement, compound 4: 1.6-fold (0.21 log units) below, and the stated range covers the measured number.
By their numbers in this assay, from the lowest: compounds 3 and 1 (each within the scatter of the next); then compounds 2 and 4 (each within the scatter of the next).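

In this assay, the 3-methylphenyl and the 3-chlorophenyl cannot be told apart, with a 1.0-fold higher number from compound 2 to compound 4 (0.01 log units; within the scatter), so replacing chloro with methyl at this spot makes no readable difference. Both methoxyphenyl compounds give lower numbers than the new compound, with a 2.8-fold higher number from compound 3 to compound 4 (0.45 log units; beyond the scatter) and a 2.1-fold higher number from compound 1 to compound 4 (0.33 log units; beyond the scatter), so the modest gap seen earlier with the 3-chlorophenyl is not tied to chlorine alone: among these four compounds, both methoxyphenyl groups give lower numbers than both 3-substituted groups, and no compound goes against this. No measured evidence offers a reason for this split.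

A 3-methoxyphenyl on the same nitrogen would show whether the gap follows the methoxy group or its place on the ring. As far as these compounds go, a 2-methylphenyl would test the same question from the methyl side, and how an unsubstituted phenyl would compare also remains open.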